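Fluorophenyl isomers at the saturated ring carbon

A few compounds are considered here, and "the series" means these few. Any claim that something is new, unique, unknown or untested is made for them only; others in the source may bear on it.

Among the measured compounds shown here, compound 2 `COc1cc(C2=NN(C(C)=O)C(c3ccccc3F)O2)cc(OC)c1OC` gives 13.5% in a functional assay on PC-3 cells (Homo sapiens) for antiproliferative activity, read by MTT assay, tested at 1 uM (on this read-out lower numbers stand for a weaker effect and higher numbers for a stronger effect at the one concentration tested), the lower of the two numbers so far; compound 1 `COc1cc(C2=NN(C(C)=O)C(c3ccc(Cl)c(Cl)c3)O2)cc(OC)c1OC` gives 28.1%. For the measured compounds named here, the one measured step, a number 14.6 percentage points lower from compound 1 to compound 2 (beyond the scatter), shows that exchanging the aryl group at this place shifts the read-out modestly. Compound 3 `COc1cc(C2=NN(C(C)=O)C(c3cccc(F)c3)O2)cc(OC)c1OC` differs from compound 2 by 3-fluorophenyl in place of 2-fluorophenyl on a saturated ring carbon. Going by the values given here, no measured pair compares two fluorophenyl groups, so the direction is open; a small move is expected, with a number 4.5 percentage points higher from compound 2 to compound 3 (within the scatter) taken slightly upward. Compound 3 is therefore estimated at 18%, within a range of 5% to 35%.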

Compound 3, a percentage reported as inhibition, at one concentration (the size of the read-out at that concentration, not a potency): 16.5%
For compound 3 the middle estimate is 1.5 percentage points above the measured one, and the stated range covers the measured number.
By their numbers in this assay, from the lowest: compounds 2 and 3 (each within the scatter of the next); then compound 1.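

In this assay, 3-fluorophenyl in place of 2-fluorophenyl on the saturated ring carbon gives a number 3 percentage points higher from compound 2 to compound 3 (within the scatter) so the two fluorophenyl isomers are not told apart here. Against 3,4-dichlorophenyl, 3-fluorophenyl gives a number 11.6 percentage points lower from compound 1 to compound 3 (beyond the scatter) so the gap first seen with compound 2 is not confined to the 2-fluorophenyl isomer. No evidence offered here bears on a cause for these numbers. Open, on these data alone, is how this carbon responds to a phenyl carrying an amine or a carboxylic acid. Also open, as far as these compounds go, is how a single chlorine on the phenyl reads.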